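The source may report more compounds than this note shows. Statements on the series, on what has been measured and on what is new or still open speak of the compounds shown alone.

Working notes on the series, measured in a functional assay on HepG2 cells (Homo sapiens) for inhibition, read by MTT assay, with a stated time of 72 h; on this read-out higher numbers stand for weaker inhibition and lower numbers for stronger inhibition. Compound 1 `O=C(OC1(C(=O)Nc2ccc([N+](=O)[O-])cc2)CCCCC1)c1ccc(Cl)cc1` gives 21.8 nM; compound 2 `O=C(OC1(C(=O)Nc2ccc([N+](=O)[O-])cc2)CCCCC1)c1ccccc1` gives 734 nM; compound 3 `CCC(=O)OC1(C(=O)Nc2ccc([N+](=O)[O-])cc2)CCCCC1` gives 21.5 nM. Compound 3 stands lowest of the three numbers, with compound 1 within the scatter of it, while the gap to compound 2 is large: a 34-fold lower number from compound 2 to compound 3 (1.53 log units; beyond the scatter) and a 1.0-fold lower number from compound 1 to compound 3 (0.01 log units; within the scatter). The next step goes to compound 4 `O=C(OC1(C(=O)Nc2ccc([N+](=O)[O-])cc2)CCCCC1)C(O)c1ccccc1`, with hydroxy(phenyl)methyl in place of ethyl on a carbonyl carbon. For the measured compounds named here, no measured step carries a hydroxy(phenyl)methyl group; the nearest bearing is the large step of a 34-fold lower number from compound 2 to compound 3 (1.53 log units; beyond the scatter), where an aromatic ring on that carbonyl carbon went with the higher number, against compound 1, where a ring gave no change. A step back toward the higher numbers is therefore expected, a 5.6-fold higher number from compound 3 to compound 4 (0.75 log units; beyond the scatter), with compound 4 estimated at 120 nM, range 20 nM to 800 nM.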

Compound 4, half-maximal inhibitory concentration: 7.7 nM
Estimate against measurement, compound 4: 16-fold (1.19 log units) above; the measured number lies below the stated range.
By their numbers in this assay, from the lowest: compound 4; then compounds 3 and 1 (each within the scatter of the next); then compound 2.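

In this assay, hydroxy(phenyl)methyl on this carbonyl carbon gives the lowest number of the series, both against ethyl (a 2.8-fold lower number from compound 3 to compound 4 (0.45 log units; beyond the scatter)) and against 4-chlorophenyl (a 2.8-fold lower number from compound 1 to compound 4 (0.45 log units; beyond the scatter)). An aromatic ring in this group therefore does not go with the higher number, and the contrast with plain phenyl is large (a 95-fold lower number from compound 2 to compound 4 (1.98 log units; beyond the scatter)). No measurement given here accounts for these steps.

As far as these compounds go, it stays open how much of the step belongs to the hydroxy group, and what an amine or a carboxylic acid in its place would give.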